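A few compounds are considered here, and "the series" means these few. Any claim that something is new, unique, unknown or untested is made for them only; others in the source may bear on it.

Measured so far in an assay on HEK293 cells for activation of Kir3.1/Kir3.2 (Homo sapiens), read by thallium flux; a lower number here means a smaller maximal response, a higher number a larger maximal response:
- compound 1 `Cc1cc(NC(=O)Cn2nnc(-c3ccccc3)n2)n(C2CCC(F)(F)CC2)n1`: 68%
- compound 2 `Cc1cc(NC(=O)Cn2nnc(-c3ccccc3)n2)n(C2CCS(=O)(=O)CC2)n1`: > 25%

In this assay compound 1 gives 68% as a full number. Compound 2 stands on a limit only: in this assay compound 2 gives > 25%, which is a limit of the assay and not a number. This rests on (the limit of > 25% in this assay, at which 1 of the 2 values shown sits). Within the data shown here, the one measured step, a step that the limit leaves unreadable from compound 1 to compound 2, is therefore of unknown size and direction, and the series holds no readable step at all.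

Compound 3 `Cc1cc(NC(=O)Cn2nnc(-c3ccccc3)n2)n(-c2ccccc2)n1` is not yet measured. It differs from compound 2 at one place: phenyl in place of 1,1-dioxothian-4-yl on an aromatic nitrogen. Among the measured compounds shown here, no measured step touches a phenyl on that aromatic nitrogen, and the only step that alters this group, a step that the limit leaves unreadable from compound 1 to compound 2, gives no size to lean on. For the measured compounds named here, compound 1, with 4,4-difluorocyclohexyl at the same place, is the sole full number and serves as the anchor.

Compound 3 is therefore expected near the level of compound 1, about 60%, within 25% to 95%, which as a step from compound 2 means an estimated step that the limit leaves unreadable from compound 2 to compound 3 against the limit.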

Compound 3, largest response reached (Emax), in percent of the reference or control that the assay uses: 66%
Beside the measured number, compound 3's estimate is 6 percentage points below it, and the stated range covers the measured number.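

In this assay, phenyl in place of 4,4-difluorocyclohexyl on the aromatic nitrogen gives a number 2 percentage points lower from compound 1 to compound 3 (within the scatter), so an aromatic ring of carbon only and a fluorinated non-aromatic ring are not told apart at this position. The position therefore now has two full numbers, and the maximal response does not depend on the ring at this nitrogen being non-aromatic, at least across these two groups. Compound 2 gives > 25% in this assay, which is a limit of the assay and not a number, so the steps that involve compound 2 cannot be read and 1,1-dioxothian-4-yl remains unplaced against the other two groups: the limit of > 25% in this assay, at which 1 of the 3 values shown sits.

Open, going by these compounds, is whether this level of response holds for a pyridine ring, a piperidine ring or an open chain such as isopropyl on the same aromatic nitrogen, or for a phenyl that itself carries a group such as methoxy or chlorine. The rest of the core stays the same throughout, so the compounds shown say nothing about how the ring methyl group or the amide linker contributes to the response.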